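This account rests on a few compounds, and the source may have more. Where it says the series, first, only, none or still open, it means among the compounds named here.

Compounds measured so far:

compound 1, `C=CS(=O)(=O)NC/C=C/c1cc(OC)cc(O)c1C(=O)OC(C)C` — 5.6%
compound 2, `CCN(CC)C/C=C/C(=O)NC/C=C/c1cc(OC)cc(O)c1C(=O)OC(C)C` — 12.5%
compound 3, `COc1cc(O)c(C(=O)OCC(C)c2ccccc2)c(/C=C/CN2C(=O)C=CC2=O)c1` — 8.6%

All three were tested in an assay on isolated protein for inhibition of MAP kinase-interacting serine/threonine-protein kinase 1 (Homo sapiens), tested at 10 uM; a lower number here means less inhibition, a higher number more inhibition at the concentration tested (going by the name of the read-out). In this assay compound 1 gives 5.6%, compound 2 gives 12.5% and compound 3 gives 8.6%. The number for compound 3 lies between the other two, but its gap to compound 1 and its gap to compound 2 both fall within the usual scatter of such measurements, so none of the three can be told apart from the others: all of them show only slight inhibition at the concentration tested.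

Compound 4, `COc1cc(O)c(C(=O)OC(C)C)c(/C=C/CN2C(=O)C=CC2=O)c1`, keeps the shared core of compound 3 and changes one place on it: isopropyl in place of 2-phenylpropyl on an oxygen next to a carbonyl group. For the measured compounds named here, no comparable pair of measured compounds exists, so there is nothing to show what this change does on its own. With the three measured numbers all low and indistinguishable, the expectation is that the step of a number 0.6 percentage points lower from compound 3 to compound 4 (within the scatter) will be none beyond the scatter. Compound 4 is therefore expected to give about 8% in this assay, with a likely range from 0% to 20%.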

Compound 4, a percentage reported as inhibition, at one concentration (the size of the read-out at that concentration, not a potency): 5.4%
Compound 4: middle estimate off by 2.6 percentage points, on the high side, within the range that was stated.
By their numbers in this assay, from the lowest: compounds 4, 1, 3 and 2 (each within the scatter of the next).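

Putting isopropyl in place of 2-phenylpropyl on an oxygen next to a carbonyl group gives, in this assay, a number 3.2 percentage points lower from compound 3 to compound 4 (within the scatter) and so shows that this place on the shared core can lose the six-membered aromatic ring, going from 9 heavy atoms to 3, without a change that can be told from the scatter. The second new comparison concerns a different place, the saturated chain carbon bound to a double-bonded chain carbon, where a group of 7 heavy atoms with a five-membered non-aromatic ring takes the place of a group of 6 heavy atoms with no ring and gives a number 0.2 percentage points lower from compound 1 to compound 4 (within the scatter) in this assay, so neither change separates its two compounds. No independent measurement is available to explain these results.

From the compounds shown here alone, whether a longer chain ending in an amine or a carboxylic acid on that same oxygen would give a step beyond the scatter remains open. Also open, going by these compounds, is whether any group at either place could lift inhibition clearly above the slight level seen so far, since a reading at one concentration gives no potency.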